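The compounds below may be only part of what the source reports. "The series", "measured", "known", "first", "only" and "open" are said of these compounds alone.

Measured so far:
Compound 1 `CN(C)CCNc1ccnc2cc(Cl)ccc12` gives > 20000 nM in a functional assay on 184B5 cells (Homo sapiens) for cytotoxicity, read by sulforhodamine B assay, with a stated time of 48 h, in the presence of a further agent that is not named here (a higher number here means a weaker inhibitor of growth, a lower number a stronger inhibitor of growth), which is a limit of the assay rather than a number.
Compound 2 `CN(C)CCNc1ccnc2cc(F)ccc12` gives > 20000 nM in this assay, again a limit and not a number.

Compound 2 therefore stands at the top of what this assay can report: its growth inhibition was too weak to be measured within the tested range. For the measured compounds named here, the only step between measured compounds, a step that the two limits leave unreadable from compound 1 to compound 2, cannot be given a size, since both of its ends are limits; this follows from the limit of > 20000 nM in this assay, at which 2 of the 2 values shown sit.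

Compound 3 `COc1ccc2c(NCCN(C)C)ccnc2c1` differs from compound 2 in one place: methoxy in place of fluoro on an aromatic carbon. Going by the values given here, no measured step covers a methoxy in place of a fluoro, and the one step that exists, fluoro in place of chloro, is unreadable in size. The expectation for compound 3 in this assay can therefore rest only on the fact that the two measured compounds sit at the limit. The step from compound 2 to compound 3 is expected to be a step that the limit leaves unreadable from compound 2 to compound 3, that is, no readable change beyond the scatter. Compound 3 is estimated at 25000 nM, with a range from 8000 nM to 70000 nM, and most likely the assay will again report only a limit.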

Compound 3, concentration for 50% growth inhibition: > 20000 nM
Compound 3: no number, only a limit; the forecaster's own chance of this, stated with the estimate: 80%; the middle value is on the limit's open side.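

In this assay compound 3 gives > 20000 nM, which is a limit and not a number. The steps joining compound 3 to compound 1 and to compound 2 cannot be read: the limit of > 20000 nM in this assay, at which 3 of the 3 values shown sit.

The compounds shown leave open whether chloro, fluoro and methoxy on the shared core differ at all in growth inhibition.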